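Cytotoxicity of Three Measured Compounds and One Untested Analogue

The compounds below may be only part of what the source reports. "The series", "measured", "known", "first", "only" and "open" are said of these compounds alone.

Measured in an ADME assay on HepG2 cells (Homo sapiens) for cytotoxicity, read by MTT assay, with a stated time of 7 days; on this read-out lower numbers stand for stronger inhibition and higher numbers for weaker inhibition:
- compound 1, `O=C(c1cccnc1)N1N=C(c2ccc(O)cc2)CC1c1ccc(F)cc1`, 52400 nM
- compound 2, `O=C(c1cccnc1)N1N=C(c2ccc(O)cc2)CC1c1ccc(Br)cc1`, 58700 nM
- compound 3, `COc1ccc(C2CC(c3ccc(O)cc3)=NN2C(=O)c2cccnc2)cc1OC`, 53600 nM

The three measured compounds share a common core and differ only in the aryl group on a saturated ring carbon. The step of a 1.1-fold higher number from compound 1 to compound 2 (0.05 log units; within the scatter) changes bromo for fluoro on an aromatic carbon; the step of a 1.0-fold higher number from compound 1 to compound 3 (0.01 log units; within the scatter) and the step of a 1.1-fold lower number from compound 2 to compound 3 (0.04 log units; within the scatter) replace the halogenated phenyl with the 3,4-dimethoxyphenyl group. None of these moves the number beyond the scatter, so in this assay compound 3 cannot be ordered against compound 1 or compound 2; its number simply sits among the others, with compound 1 nearest and compound 2 furthest.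

Compound 4, `CCc1ccccc1C1CC(c2ccc(O)cc2)=NN1C(=O)c1cccnc1`, continues this series. Its change from compound 3 is 2-ethylphenyl in place of 3,4-dimethoxyphenyl on a saturated ring carbon. The two steps that bear on it, a 1.0-fold higher number from compound 1 to compound 3 (0.01 log units; within the scatter) and a 1.1-fold lower number from compound 2 to compound 3 (0.04 log units; within the scatter), both swap one aryl group for another at this same saturated ring carbon, and both stayed within the scatter. On that basis compound 4 is expected to show no step beyond the scatter in this assay, that is, an estimated 1.0-fold lower number from compound 3 to compound 4 (0.01 log units; within the scatter). The estimate for compound 4 is therefore 52000 nM, with a range from 28000 nM to 100000 nM.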

Compound 4, half-maximal inhibitory concentration: 35400 nM
Compound 4: the middle estimate sits 1.5-fold (0.17 log units) above what was measured; measured number inside the range.
By their numbers in this assay, from the lowest: compounds 4, 1, 3 and 2 (each within the scatter of the next).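

At the saturated ring carbon of the shared core, compounds 1, 2 and 3 carried only a 4-fluorophenyl, a 4-bromophenyl or a 3,4-dimethoxyphenyl group, whereas compound 4 shows that a 2-ethylphenyl group, with its 0 hydrogen-bond acceptors, also leaves the number in this assay within the scatter of all three. Putting it in place of 3,4-dimethoxyphenyl gives a 1.5-fold lower number from compound 3 to compound 4 (0.18 log units; within the scatter) and in place of 4-bromophenyl gives a 1.7-fold lower number from compound 2 to compound 4 (0.22 log units; within the scatter) and in place of 4-fluorophenyl gives a 1.5-fold lower number from compound 1 to compound 4 (0.17 log units; within the scatter) and so compound 4 cannot be ranked against any of the others, even though these aryl groups differ in what they carry and where they carry it. No measurement at hand accounts for why the numbers stay this close together.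

The compounds shown leave open whether the number would stay within the scatter with an amine or a carboxylic acid on this aryl ring, or with a longer chain such as butyl in place of the ethyl group. They also leave open how far the number depends on the 4-hydroxyphenyl and (pyridin-3-yl)carbonyl groups, which all four compounds keep.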